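This account rests on a few compounds, and the source may have more. Where it says the series, first, only, none or still open, it means among the compounds named here.

Compound 1 `COc1ccc2c(c1)[C@@H](O)CN(C)C2` gives > 100000 nM in an ADME assay on Vero cells (Chlorocebus sabaeus) for cytotoxicity, read by sulforhodamine B assay, with a stated time of 72 h (on this read-out lower numbers stand for stronger inhibition and higher numbers for weaker inhibition), which is a limit of the assay rather than a number.
Compound 2 `CN1Cc2ccc(OCc3ccc(Oc4ccccc4)cc3)cc2[C@@H](O)C1` gives 3400 nM in this assay.
Compound 3 `CN1Cc2ccc(OCc3ccc(Oc4ccc(F)cc4)cc3)cc2[C@@H](O)C1` gives 5600 nM in this assay.

For the measured compounds named here, compound 3 sits within the scatter of the only other number, as the step of a 1.6-fold higher number from compound 2 to compound 3 (0.22 log units; within the scatter) shows. Compound 4 `CN1Cc2ccc(OCc3ccc(-c4ccc(F)cc4)cc3)cc2[C@@H](O)C1` differs from compound 3 in one place: 4-fluorophenyl in place of 4-fluorophenoxy on an aromatic carbon. Going by the values given here, no measured step exchanges 4-fluorophenoxy for 4-fluorophenyl, and the single measured step in this assay stays within the scatter. The expected step of a 1.1-fold lower number from compound 3 to compound 4 (0.05 log units; within the scatter) for compound 4 is therefore small, in no clear direction beyond the scatter. Compound 4 is estimated to give about 5000 nM in this assay, with a range from 2000 nM to 15000 nM.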

Compound 4, half-maximal inhibitory concentration: 33800 nM
Beside the measured number, compound 4's estimate is 6.8-fold (0.83 log units) below it; measured number outside the range, above it.
By their numbers in this assay, from the lowest: compounds 2 and 3 (each within the scatter of the next); then compound 4. At a limit, above all of these: compound 1.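

Replacing 4-fluorophenoxy with 4-fluorophenyl gives a 6.0-fold higher number from compound 3 to compound 4 (0.78 log units; beyond the scatter) in this assay, so this position responds to the change, whereas adding fluoro did not move the number beyond the scatter. Replacing phenoxy with 4-fluorophenyl likewise gives a 9.9-fold higher number from compound 2 to compound 4 (1.00 log units; beyond the scatter), which means weaker inhibition of the cells. Nothing measured here explains why the number rises.

Still open, going by these compounds, is whether the rise follows from losing the oxygen atom alone. An amine or a methylene linker in its place could test this.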